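Rearranging the aryl tail on a shared core

The source may report more compounds than this note shows. Statements on the series, on what has been measured and on what is new or still open speak of the compounds shown alone.

Three analogues sharing one core have been measured in an assay on CHO cells for displacement of a labelled ligand from adenosine receptor A3 (Homo sapiens), read by scintillation counting, tested at 1 uM; on this read-out higher numbers stand for more inhibition at the one concentration tested (going by the name of the read-out) and lower numbers for less inhibition. Compound 1 `CC(C)Cc1nc(N)c2nn(-c3ccccc3)cc2n1` gives 13%. Compound 2 `COc1ccc(Cc2nc(N)c3nn(-c4ccccc4)cc3n2)cc1` gives 38%, and a number 25 percentage points higher from compound 1 to compound 2 (beyond the scatter). Compound 3 `COc1ccc(CCc2nc(N)c3nn(-c4ccccc4)cc3n2)cc1` gives 22%, the second highest of the three numbers; its nearest neighbour is compound 1, within the scatter, while compound 2 stands beyond the scatter above it. Compound 4 `Nc1nc(CCCc2ccccc2O)nc2cn(-c3ccccc3)nc12` has not yet been measured. It differs from compound 3 by 2-hydroxybenzyl in place of 4-methoxyphenyl on a saturated chain carbon, two bonds along the chain from an aromatic carbon. No measured step bears directly on this change: the only step, a number 25 percentage points higher from compound 1 to compound 2 (beyond the scatter), replaced one group on the chain by another rather than rejoining the same atoms, and the pair of compound 2 at 38% and compound 3 at 22% shows only a fall beyond the scatter without a listed step. Among the compounds with values here, with the same atoms joined differently and no comparable precedent, for compound 4 the expected step is a number 2 percentage points lower from compound 3 to compound 4 (within the scatter), small and within the scatter in either direction. Compound 4 is therefore estimated at 20%, with a range from 5% to 40%.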

Compound 4, a percentage reported as inhibition, at one concentration (the size of the read-out at that concentration, not a potency): 36%
Compound 4: the middle estimate sits 16 percentage points below what was measured; the range from low to high includes it.
By their numbers in this assay, from the lowest: compounds 1 and 3 (each within the scatter of the next); then compounds 4 and 2 (each within the scatter of the next).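

In this assay, putting 2-hydroxybenzyl in place of 4-methoxyphenyl on a saturated chain carbon, two bonds along the chain from an aromatic carbon, gives a number 14 percentage points higher from compound 3 to compound 4 (beyond the scatter). This is the first step shown in which the atoms stay the same and only their joining changes, so the number at this position depends on how the tail is arranged and not on its atom count alone; the entering group has 1 hydrogen-bond donor and the leaving group 0 hydrogen-bond donors. Nothing available explains the rise.

The compounds shown do not separate the hydroxyl from the rearranged tail, a question that 2-methoxybenzyl or 4-hydroxybenzyl in the same place would address. Also open, from the compounds shown here alone, is whether an amine or a carboxylic acid in place of the hydroxyl, or a longer chain, would keep this step.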